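This account rests on a few compounds, and the source may have more. Where it says the series, first, only, none or still open, it means among the compounds named here.

Values in a functional assay on HeLa cells (Homo sapiens) for antiproliferative activity, read by MTT assay, with a stated time of 48 h (on this read-out higher numbers stand for weaker inhibition and lower numbers for stronger inhibition), are as follows:
Compound 1 `c1ccc(-c2nn(-c3ccccc3)cc2-c2nc3ccccc3[nH]2)cc1` gives 1550 nM
Compound 2 `Brc1ccc2[nH]c(-c3cn(-c4ccccc4)nc3-c3ccccc3)nc2c1` gives 1760 nM
Compound 3 `FC(F)(F)c1ccc2[nH]c(-c3cn(-c4ccccc4)nc3-c3ccccc3)nc2c1` gives 1920 nM

Compound 1 lies within the scatter of both compound 2 and compound 3, so these three cannot be ranked. Compound 4 `Clc1ccc(-c2nn(-c3ccccc3)cc2-c2nc3ccccc3[nH]2)cc1` differs from compound 1 by one change, chloro in place of hydrogen on an aromatic carbon. The nearest guides are a 1.1-fold higher number from compound 1 to compound 2 (0.06 log units; within the scatter) and a 1.2-fold higher number from compound 1 to compound 3 (0.09 log units; within the scatter), and both are small, although neither change is made at the same place as in compound 4. No step beyond the scatter is therefore expected, in either direction. For compound 4 the expected step is a 1.1-fold higher number from compound 1 to compound 4 (0.04 log units; within the scatter) in this assay. The estimate for compound 4 is 1700 nM, with an expected range from 900 nM to 3200 nM.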

Compound 4, half-maximal inhibitory concentration: 1650 nM
Compound 4: middle estimate off by 1.0-fold (0.01 log units), on the high side; measured number inside the range.
By their numbers in this assay, from the lowest: compounds 1, 4, 2 and 3 (each within the scatter of the next).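

Within this assay the change from phenyl to 4-chlorophenyl gives a 1.1-fold higher number from compound 1 to compound 4 (0.03 log units; within the scatter) and so no readable change in the number. Among these compounds, this is the first view of a change at this place, on an aromatic carbon para to a large group, since the bromo and trifluoromethyl compounds were changed elsewhere on the core. Nothing available explains this result.

As far as these compounds go, whether an amine or a carboxylic acid at this same place would shift the number beyond the scatter remains open. So does whether a methoxy group would behave like chloro here.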